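The source may hold more compounds than are shown below. What is called first, only, known or untested is meant among the compounds shown, and "the series" means these compounds.

Working notes on the hydroxamic series around the shared core of compound 1 `O=C(CCC1CCCC1)N(O)c1ccc(Cl)cc1`. For the measured compounds named here, in a functional assay on MOLT-4 cells (Homo sapiens) for inhibition (on this read-out lower numbers stand for stronger inhibition and higher numbers for weaker inhibition), compound 1 gives 28000 nM, the second highest of the three numbers so far. Compound 2 `O=C(C1CCCCC1)N(O)c1ccc(Cl)cc1` gives 19000 nM in this assay, and compound 3 `O=C(CC1CCCCC1)N(O)c1ccc(Cl)cc1` gives 33000 nM; all three numbers sit within the scatter of one another, so no order among them can be read.

Compound 4 `O=C(CCC1CCCCC1)N(O)c1ccc(Cl)cc1` is not yet measured. It differs from compound 1 by cyclohexyl in place of cyclopentyl on a saturated chain carbon, two bonds along the chain from a carbonyl carbon. Going by the values given here, the only measured step touching this part of the molecule is a 1.2-fold higher number from compound 1 to compound 3 (0.07 log units; within the scatter), a change at the same chain carbon that left the number essentially where it was. The values of compound 2 and compound 3 likewise show no separation beyond the scatter. On that basis no step beyond the scatter is expected in this assay for the move to compound 4; the expected step is a 1.1-fold higher number from compound 1 to compound 4 (0.03 log units; within the scatter). For compound 4 the estimate is 30000 nM, with a range from 12000 nM to 75000 nM.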

Compound 4, half-maximal inhibitory concentration: 24000 nM
Compound 4: the middle estimate sits 1.3-fold (0.10 log units) above what was measured, within the range that was stated.
By their numbers in this assay, from the lowest: compounds 2, 4, 1 and 3 (each within the scatter of the next).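

In this assay, the change of ring size alone gives a 1.2-fold lower number from compound 1 to compound 4 (0.07 log units; within the scatter): cyclohexyl in place of cyclopentyl on a saturated chain carbon, two bonds along the chain from a carbonyl carbon, leaves the number within the scatter. The earlier step, a 1.2-fold higher number from compound 1 to compound 3 (0.07 log units; within the scatter), exchanged the ring and the chain attachment together, so it could not show the effect of ring size separately; compound 4 now supplies that single change. Nothing measured here offers a reason for this flat result.

All four compounds shown end in a carbon-only ring, so the effect of an amine or a carboxylic acid at this end of the chain stays open. Also open, going by these compounds, is whether any replacement here would move the number in this assay beyond the scatter.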